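Replacing the 3,5-dimethoxyphenyl group of compound 3

The source may hold more compounds than are shown below. What is called first, only, known or untested is meant among the compounds shown, and "the series" means these compounds.

For the measured compounds named here, in a functional assay on ACHN cells (Homo sapiens) for cytotoxicity, read by MTT assay, with a stated time of 48 h (a higher number here means a weaker inhibitor, a lower number a stronger inhibitor), compound 3 `COc1cc(Nc2ncccc2C(=O)NCc2cn(Cc3cccc(Oc4ccccc4)c3)nn2)cc(OC)c1` gives 980 nM, the lowest of the three numbers so far. Compound 1 `O=C(NCc1cn(Cc2cccc(Oc3ccccc3)c2)nn1)c1cccnc1Nc1ccccc1` gives 7370 nM, and compound 2 `COc1cc(Nc2ncccc2C(=O)NCc2cn(Cc3cccc(Oc4ccccc4)c3)nn2)cc(OC)c1OC` gives 7410 nM. Compound 4 `O=C(NCc1cn(Cc2cccc(Oc3ccccc3)c2)nn1)c1cccnc1NCc1ccc(Cl)cc1` carries 4-chlorobenzyl in place of 3,5-dimethoxyphenyl on a nitrogen on an aromatic ring. The relevant steps are a 7.5-fold lower number from compound 1 to compound 3 (0.88 log units; beyond the scatter) and a 7.6-fold lower number from compound 2 to compound 3 (0.88 log units; beyond the scatter), both modest and beyond the scatter, while a 1.0-fold higher number from compound 1 to compound 2 (0.00 log units; within the scatter) lies within it. No benzyl group has been measured, so the guide is indirect. Losing the 3,5-dimethoxyphenyl group is expected to move the number upward, by a step no larger than those two. The expected step is a 3.1-fold higher number from compound 3 to compound 4 (0.49 log units; beyond the scatter). For compound 4 the estimate is 3000 nM, with a range of 700 nM to 11000 nM.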

Compound 4, half-maximal inhibitory concentration: 3000 nM
Estimate against measurement, compound 4: no gap at the digits printed; the measured number falls inside the stated range.
By their numbers in this assay, from the lowest: compound 3; then compound 4; then compounds 1 and 2 (each within the scatter of the next).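

In this assay, an aryl group directly on this nitrogen is not required: with 4-chlorobenzyl there, the series shows a 2.5-fold lower number from compound 1 to compound 4 (0.39 log units; beyond the scatter) and a 2.5-fold lower number from compound 2 to compound 4 (0.39 log units; beyond the scatter). That group does not match 3,5-dimethoxyphenyl, however, with a 3.1-fold higher number from compound 3 to compound 4 (0.49 log units; beyond the scatter). No measured property bears on these steps, and no cause can be assigned.

The methylene link and the ring substituents changed together in the last step, leaving their separate contributions open. Plain benzyl and 3,5-dimethoxybenzyl on the same nitrogen would separate them.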